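Swapping Acetamido for Dimethylamino on an Oxime Ether Acid

The compounds below may be only part of what the source reports. "The series", "measured", "known", "first", "only" and "open" are said of these compounds alone.

Three oxime-ether carboxylic acids have been tested in a functional assay on the whole organism for inhibition, with Rattus norvegicus as the target, read by paw edema, with stated times of 1 h and 3 h, at a dose of 50 mg/kg by the oral route; a lower number here means less inhibition, a higher number more inhibition at the dose given (going by the name of the read-out). The simplest is compound 1, `C/C(=N\OCC(=O)O)c1ccccc1`. In this assay compound 1 gives < 20%, which is a limit of the measurement rather than a number. Compound 2, `C/C(=N\OCC(=O)O)c1ccc(CC2CCCCC2)cc1`, carries a cyclohexylmethyl group on the aromatic ring. In this assay compound 2 gives < 20%, again only a limit. Compound 3, `CC(=O)Nc1ccc(/C(C)=N/OCC(=O)O)cc1`, carries an acetamido group in that position instead. In this assay compound 3 gives < 20%, also a limit. Because of the limit of < 20% in this assay, at which 3 of the 3 values shown sit, none of the steps between these compounds can be sized: a step that the two limits leave unreadable from compound 1 to compound 2, a step that the two limits leave unreadable from compound 1 to compound 3 and a step that the two limits leave unreadable from compound 2 to compound 3 all remain unreadable.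

Compound 4, `C/C(=N\OCC(=O)O)c1ccc(N(C)C)cc1`, has not yet been measured. It differs from compound 3 in one place: dimethylamino in place of acetamido on an aromatic carbon. Within the data shown here, no measured step addresses this particular exchange, and the three steps that do exist in this assay are unreadable, so nothing supports expecting a move beyond the scatter in either direction. For compound 4 the expected value in this assay is therefore 12%, most likely lying between 0% and 30%. The expected step that the limit leaves unreadable from compound 3 to compound 4 is, in other words, close to nothing.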

Compound 4, a percentage reported as inhibition, in the whole organism at one dose (the size of the read-out at that dose, not a potency): < 20%
Compound 4: no number, only a limit; the forecaster's own chance of this, stated with the estimate: 70%; the middle value lies beyond the limit too.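

In this assay compound 4 gives < 20%, which is a limit and not a number. The steps to compound 4 from compound 1, compound 2 and compound 3 cannot be read, because all four compounds share one limit: the limit of < 20% in this assay, at which 4 of the 4 values shown sit. The compounds shown leave open whether exchanging the group on the aromatic ring changes inhibition at all.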